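The source may report more compounds than this note shows. Statements on the series, on what has been measured and on what is new or still open speak of the compounds shown alone.

Measured so far:
compound 1, `COc1cccc(N2C(=O)COc3ccc(-c4cnc(Cl)c(NS(=O)(=O)c5ccc(F)cc5)c4)cc32)c1` — in a functional assay on MCF7 cells (Homo sapiens) for antiproliferative activity, read by MTT assay, with a stated time of 72 h (on this read-out lower numbers stand for stronger inhibition and higher numbers for weaker inhibition), compound 1 gives > 40000 nM, a limit.
compound 2, `COc1cccc(N2C(=O)COc3ccc(-c4cnc(OC)c(NS(=O)(=O)c5ccc(F)cc5)c4)cc32)c1` — in this assay compound 2 gives > 40000 nM, a limit.

Compound 1 stands at a limit only; both values shown sit at the limit of > 40000 nM in this assay, at which 2 of the 2 values shown sit. Among the compounds with values here, the one measured step, a step that the two limits leave unreadable from compound 1 to compound 2, cannot be read and does not touch the group changed here. Compound 3, `O=C1COc2ccc(-c3cnc(Cl)c(NS(=O)(=O)c4ccc(F)cc4)c3)cc2N1c1ccc(F)cc1`, differs from compound 1 by 4-fluorophenyl in place of 3-methoxyphenyl on an amide-type nitrogen in a ring. Within the data shown here, no measured step bears on this change, so no size is expected beyond the scatter in this assay, and a number no higher from compound 1 to compound 3 (the limit leaves the size open) is expected to be flat. Compound 3 is estimated at 40000 nM, in the range 10000 nM to 100000 nM.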

Compound 3, half-maximal inhibitory concentration: 32600 nM
The estimate for compound 3 lay 1.2-fold (0.09 log units) above the measured number; the range from low to high includes it.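

In this assay, within the data shown here, compound 3 gives 32600 nM, the only value shown that is a number and not a limit. Placing 4-fluorophenyl on the amide-type nitrogen in a ring gives an at least 1.2-fold lower number from compound 1 to compound 3 (0.08 log units; that floor lies within the scatter), so this change supports no claim of a gain beyond the scatter. The size of the step stays open, as compound 1 is held at a limit: the limit of > 40000 nM in this assay, at which 2 of the 3 values shown sit.

The compounds shown leave open whether an aminophenyl or carboxyphenyl group on this nitrogen would move the number beyond the scatter.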